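The compounds below may be only part of what the source reports. "The series", "measured", "known", "first", "only" and "open" are said of these compounds alone.

For the measured compounds named here, in a functional assay on HCT-116 cells (Homo sapiens) for cytotoxicity, read by MTT assay, with a stated time of 72 h (a higher number here means a weaker inhibitor, a lower number a stronger inhibitor), compound 2 (`COc1ncc(-c2ccc3nc(NC(=O)N(C)C)nn3c2)cc1NS(=O)(=O)c1ccc(F)cc1`) gives 760 nM, the higher of the two numbers measured so far. The other measured compound, compound 1 (`COc1ncc(-c2ccc3nc(NC(=O)NCC(=O)N4CCCCC4)nn3c2)cc1NS(=O)(=O)c1ccc(F)cc1`), gives 130 nM. Compound 3 (`COc1ncc(-c2ccc3nc(NC(=O)NCCN4CCCC4)nn3c2)cc1NS(=O)(=O)c1ccc(F)cc1`) keeps the core of compound 2 and alters a single group: (2-(pyrrolidin-1-yl)ethyl)amino in place of dimethylamino on a carbonyl carbon. In words, (2-(pyrrolidin-1-yl)ethyl)amino takes the place of dimethylamino on a carbonyl carbon. Going by the values given here, one measured step bears on this change, because the same dimethylamino group is involved in a 5.8-fold higher number from compound 1 to compound 2 (0.77 log units; beyond the scatter). Read in reverse, that step links a larger group at this place with a lower number. The entering chain is a different one, however, and a single pair is thin evidence. The expected result is a 4.2-fold lower number from compound 2 to compound 3 (0.63 log units; beyond the scatter), a drop of comparable size. For compound 3, the estimated value is 180 nM, with an expected range of 55 nM to 600 nM.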

Compound 3, half-maximal inhibitory concentration: 230 nM
For compound 3 the middle estimate is 1.3-fold (0.11 log units) below the measured one; the measured number falls inside the stated range.
By their numbers in this assay, from the lowest: compounds 1 and 3 (each within the scatter of the next); then compound 2.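

In this assay, (2-(pyrrolidin-1-yl)ethyl)amino in place of dimethylamino on the carbonyl carbon gives a 3.3-fold lower number from compound 2 to compound 3 (0.52 log units; beyond the scatter), so a second, different larger group at this place also goes with a lower number than dimethylamino. The two larger groups themselves cannot be told apart here: (pyrrolidin-1-yl)methyl in place of (piperidin-1-yl)carbonyl on the chain gives a 1.8-fold higher number from compound 1 to compound 3 (0.25 log units; within the scatter), so swapping the carbonyl-linked piperidine for the pyrrolidine chain makes no clear difference. Nothing available explains why these changes shift the number.

The compounds shown leave open whether the ring in these groups matters at all, or whether the longer chain alone is enough. A plain ethylamino or butylamino group at this place would separate the two, and a morpholine ring on the same chain would show how far the ring can vary.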